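The compounds below may be only part of what the source reports. "The series", "measured", "known", "first", "only" and "open" are said of these compounds alone.

Of the compounds shown here, three built on one shared core have been measured in a physicochemical assay for lipophilicity, read by HPLC, measured as octanol-water partition; on this read-out lower numbers stand for lower lipophilicity and higher numbers for higher lipophilicity. Compound 1 `CN1CCN(C[C@H]2CN(c3ccc(-n4cc(-c5ccccn5)cn4)c(F)c3)C(=O)O2)CC1` gives 2.2, compound 2 `O=C1CCC(=O)N1C[C@H]1CN(c2ccc(-n3cc(-c4ccccn4)cn3)c(F)c2)C(=O)O1` gives 1.58, and compound 3 `O=C1CNC(=O)N1C[C@H]1CN(c2ccc(-n3cc(-c4ccccn4)cn3)c(F)c2)C(=O)O1` gives 1.25, the lowest of the three. The steps of a number 0.95 log units lower from compound 1 to compound 3 (beyond the scatter) and a number 0.33 log units lower from compound 2 to compound 3 (beyond the scatter) show that each change leading to compound 3 lowered this assay beyond the scatter. Compound 4 `O=C(OC[C@H]1CN(c2ccc(-n3cc(-c4ccccn4)cn3)c(F)c2)C(=O)O1)c1ccccc1` differs from compound 3 by benzoyloxy in place of 2,5-dioxoimidazolidin-1-yl on a saturated chain carbon bound to a saturated ring carbon. For the measured compounds named here, no measured step mirrors this exact change, so the two steps into compound 3 bear on it only by placing the leaving group at the low end. Swapping it for a larger aromatic ester is expected to raise this assay by a number 1.85 log units higher from compound 3 to compound 4 (beyond the scatter). Compound 4 is therefore estimated at 3.1, within 2.5 to 3.7.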

Compound 4, partition coefficient: 4.21
Compound 4: the middle estimate sits 1.11 log units below what was measured; measured number above the stated range.
By their numbers in this assay, from the lowest: compound 3; then compound 2; then compound 1; then compound 4.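

In this assay, for the compounds shown here, benzoyloxy on a saturated chain carbon bound to a saturated ring carbon gives a number 2.96 log units higher from compound 3 to compound 4 (beyond the scatter) and a number 2.63 log units higher from compound 2 to compound 4 (beyond the scatter) and a number 2.01 log units higher from compound 1 to compound 4 (beyond the scatter), so the group at this place can move the number much further than the earlier compounds showed. Compound 4 alone carries a six-membered aromatic ring and an oxygen link here, and these two features enter together, so the steps cannot separate them. Nothing available explains the size of these steps.

As far as these compounds go, how an acetoxy group, which keeps the ester without the aromatic ring, or a phenoxy group, which keeps the ring without the carbonyl, would read in this assay stays open.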